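Benzylamide in Place of Ester on a Pyrazole Carbonyl

A few compounds are considered here, and "the series" means these few. Any claim that something is new, unique, unknown or untested is made for them only; others in the source may bear on it.

Measured so far:
compound 1, `C=CCc1cc(-c2sc(NC(=O)C(C)(C)C)nc2C)nn1C(=O)Nc1ccc(OC)cc1`: 933 nM
compound 2, `CCOC(=O)n1nc(-c2sc(NC(=O)C(C)(C)C)nc2C)cc1Cc1ccccc1`: 8510 nM

In an assay on cells with Cystic fibrosis transmembrane conductance regulator variant F508del (Homo sapiens) as the target, read by fluorescence, with stated times of 24 h and 30 min (on this read-out lower numbers stand for an effect already at smaller amounts and higher numbers for an effect only at larger amounts of compound), compound 2 gives 8510 nM, the highest of the two numbers, and its nearest neighbour, compound 1, lies at a lower number beyond the scatter. Compound 3, `Cc1nc(NC(=O)C(C)(C)C)sc1-c1cc(Cc2ccccc2)n(C(=O)NCc2ccccc2)n1`, differs from compound 2 by benzylamino in place of ethoxy on a carbonyl carbon. Going by the values given here, no step between measured compounds with this change is available, so the expectation rests on the two values alone. Compound 1, which carries a urea on the same carbonyl carbon, gives 933 nM in this assay, and compound 3 also carries a nitrogen on that carbonyl; the step of a 4.7-fold lower number from compound 2 to compound 3 (0.67 log units; beyond the scatter) is therefore expected to run toward a lower number, beyond the scatter. For compound 3 the estimated value in this assay is 1800 nM, with a range from 450 nM to 6500 nM.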

Compound 3, half-maximal effective concentration: 759 nM
Compound 3: the middle estimate sits 2.4-fold (0.38 log units) above what was measured; measured number inside the range.
By their numbers in this assay, from the lowest: compounds 3 and 1 (each within the scatter of the next); then compound 2.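

In this assay, going by these compounds alone, the change on the carbonyl carbon produces an 11-fold lower number from compound 2 to compound 3 (1.05 log units; beyond the scatter) and gives the first direct comparison at this position, with the rest of the molecule unchanged. The result shows that this position is sensitive to the group on the carbonyl carbon, since benzylamino and ethoxy are not interchangeable here. The change brings in the amide hydrogen and an aromatic ring together, so this single step cannot assign its size to either one, and no available evidence bears on the reason for it.

The compounds shown leave open whether the nitrogen or the ring accounts for the step, which a methylamino or a benzyloxy group on the same carbonyl carbon would help separate. A phenethylamino group would show whether the step persists with a longer chain.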